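Chloro for fluoro at the assay limit

The source may hold more compounds than are shown below. What is called first, only, known or untested is meant among the compounds shown, and "the series" means these compounds.

In an ADME assay on BJ cells (Homo sapiens) for cytotoxicity, read by luminescence, with a stated time of 72 h (a higher number here means that more compound is needed for the effect, a lower number that less compound is needed), compound 2 (`CCOC(=O)c1c(-c2cccc(F)c2)[nH]c2cc(OC)c(F)cc2c1=O`) gives > 21500 nM, which is a limit and not a number. Compound 3 (`CCOC(=O)c1c(-c2cccc(Cl)c2)[nH]c2cc(OC)c(F)cc2c1=O`) has 3-chlorophenyl in place of 3-fluorophenyl: chloro in place of fluoro on an aromatic carbon. Compound 1 (`CCOC(=O)c1c(-c2cccc(Cl)c2)[nH]c2cc(OC)c(Cl)cc2c1=O`) carries the same 3-chlorophenyl and gives > 21500 nM, also a limit. The two measured compounds stand at the limit of > 21500 nM in this assay, at which 2 of the 2 values shown sit, so no step beyond the scatter is expected in this assay, in either direction. The estimated change is a step that the limit leaves unreadable from compound 2 to compound 3. For compound 3 the expected value is 30000 nM, with an estimated range of 15000 nM to 60000 nM.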

Compound 3, half-maximal effective concentration: > 21500 nM
Compound 3: a limit, no number; the forecaster's own chance of this, stated with the estimate: 85%; the middle value is on the limit's open side.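

No step can be read among compound 1, compound 2 and compound 3 in this assay, as each result is a limit and not a number: the limit of > 21500 nM in this assay, at which 3 of the 3 values shown sit.

The compounds shown leave open whether chloro and fluoro on an aromatic carbon differ at all in this assay.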